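Swapping an aryl group among compounds at a limit

This account rests on a few compounds, and the source may have more. Where it says the series, first, only, none or still open, it means among the compounds named here.

In a physicochemical assay for solubility, at pH 7.9 (a lower number here means a less soluble compound, a higher number a more soluble compound), three compounds are measured, each only as a limit:
Compound 1 `O=c1c(-c2ccccc2)cn(C2CC2)c2cc(N3CCNCC3)c(F)cc12` gives > 400000 nM as a limit
Compound 2 `COc1ccc(-c2cn(C3CC3)c3cc(N4CCNCC4)c(F)cc3c2=O)cc1` gives > 400000 nM as a limit
Compound 3 `O=c1c(-c2cccc(F)c2)cn(C2CC2)c2cc(N3CCNCC3)c(F)cc12` gives > 400000 nM as a limit

On the numbers shown, compound 2 has only the limit > 400000 nM to stand on. The whole series rests on the limit of > 400000 nM in this assay, at which 3 of the 3 values shown sit, and on no exact reading.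

Compound 4 `O=c1c(-c2cccc(Cl)c2)cn(C2CC2)c2cc(N3CCNCC3)c(F)cc12` differs from compound 2 by 3-chlorophenyl in place of 4-methoxyphenyl on an aromatic carbon.

Among the measured compounds shown here, three measured steps bear on this swap. The closest is a step that the two limits leave unreadable from compound 2 to compound 3 and it is the same kind of exchange, with 3-fluorophenyl entering in place of 4-methoxyphenyl. The other two are a step that the two limits leave unreadable from compound 1 to compound 2 and a step that the two limits leave unreadable from compound 1 to compound 3 and they put methoxy or fluoro in place of hydrogen on an aromatic carbon. None of the three has a readable size, so none gives a direction.

Compound 3 carries the most similar group and gives > 400000 nM as a limit as well. On that ground, no step beyond the usual scatter is expected in this assay and no direction can be named. The expected step is a number no higher from compound 2 to compound 4 (the limit leaves the size open) and no more than that. Compound 4 is expected to give 400000 nM with an estimated range from 200000 nM to 600000 nM and the reading may well be a limit again.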

Compound 4, solubility: > 400000 nM
Compound 4 ended at the assay's limit; the forecaster's own chance of this, stated with the estimate: 85%; the middle value sits exactly at the limit.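

In this assay, compound 4 gives > 400000 nM, and this is a limit, not an exact number. The steps to compound 4 from compound 1, compound 2 and compound 3 therefore cannot be read. The compounds shown leave open how soluble any of the four really is, and whether swapping the aryl group changes that at all.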